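Swapping the pyridine on the side chain of compound 2

A few compounds are considered here, and "the series" means these few. Any claim that something is new, unique, unknown or untested is made for them only; others in the source may bear on it.

Measured in a functional assay for inhibition, with Homo sapiens as the target; on this read-out higher numbers stand for weaker inhibition and lower numbers for stronger inhibition:
- compound 1 `CC(C)(C)Sc1c(CC(C)(C)C(=O)O)n(Cc2ccc(Cl)cc2)c2ccc(CCc3ccc4ccccc4n3)cc12`: 4 nM
- compound 2 `CC(C)(C)Sc1c(CC(C)(C)C(=O)O)n(Cc2ccc(Cl)cc2)c2ccc(OCc3ccncc3)cc12`: 6 nM

Within the data shown here, compound 2 cannot be separated from the only other measured compound, and this one step is all that bears on the next change: a 1.5-fold higher number from compound 1 to compound 2 (0.18 log units; within the scatter). That step lies within the scatter despite a larger replacement at the same site of the shared core. Compound 3 `CC(C)(C)Sc1c(CC(C)(C)C(=O)O)n(Cc2ccc(Cl)cc2)c2ccc(OCc3cccc(Cl)n3)cc12` differs from compound 2 as follows: 6-chloropyridin-2-yl in place of pyridin-4-yl on a saturated chain carbon bound to an oxygen on an aromatic ring. Among the measured compounds shown here, no measured compound carries a chlorinated pyridine, so the reading is uncertain. The expected step in this assay is no change at the digits printed from compound 2 to compound 3 (within the scatter), with none expected beyond the scatter. For compound 3 the estimated value is 6 nM, with an expected range of 2.5 nM to 16 nM.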

Compound 3, half-maximal inhibitory concentration: 3 nM
Compound 3: the middle estimate sits 2.0-fold (0.30 log units) above what was measured; measured number inside the range.
By their numbers in this assay, from the lowest: compounds 3, 1 and 2 (each within the scatter of the next).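

Among these compounds, a chlorinated pyridine on this saturated chain carbon stays level with the earlier compounds in this assay, with a 2.0-fold lower number from compound 2 to compound 3 (0.30 log units; within the scatter). The whole (6-chloropyridin-2-yl)methoxy group also cannot be separated from 2-(quinolin-2-yl)ethyl, with a 1.3-fold lower number from compound 1 to compound 3 (0.12 log units; within the scatter). No data are available to explain this tolerance.

The step changes both the chlorine and the ring attachment, so plain pyridin-2-yl would be needed to separate the two. From the compounds shown here alone, whether an amine or a carboxylic acid in place of the chlorine would move the number beyond the scatter remains open.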